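The compounds below may be only part of what the source reports. "The series", "measured", "known", "first", "only" and "open" are said of these compounds alone.

Among the compounds with values here, compound 2 `O=C(O)c1ccc(CCCN2C(=O)CC[C@@H]2CCC(O)Cc2ccccc2)s1` gives 21 nM in an assay on HEK293 cells for binding affinity to prostaglandin E2 receptor EP4 subtype (Rattus norvegicus) (a lower number here means a stronger inhibitor, a higher number a weaker inhibitor), the lowest of the three numbers measured so far. Compound 1 `O=C(O)CCCCCCN1C(=O)CC[C@@H]1CCC(O)Cc1ccccc1` gives 54 nM in this assay, and compound 3 `O=C(O)c1ccc(CCCN2C(=O)CC[C@@H]2CCC(O)Cc2cccc(-c3ccccc3)c2)s1` gives 50 nM. Compound 4 `CCc1ccc(CC(O)CC[C@H]2CCC(=O)N2CCCc2ccc(C(=O)O)s2)cc1` differs from compound 2 by ethyl in place of hydrogen on an aromatic carbon. Of the measured steps, only a 2.4-fold higher number from compound 2 to compound 3 (0.38 log units; beyond the scatter) bears on this change, since it also adds a group on that same ring. The step of a 2.6-fold lower number from compound 1 to compound 2 (0.41 log units; beyond the scatter) alters the acid end and says nothing here. Ethyl, which has no ring, is expected to cost less than the phenyl added in compound 3, so a step of a 1.4-fold higher number from compound 2 to compound 4 (0.15 log units; within the scatter) in this assay is expected. Compound 4 is therefore estimated at 30 nM, with a range from 12 nM to 80 nM.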

Compound 4, half-maximal inhibitory concentration: 140 nM
For compound 4 the middle estimate is 4.7-fold (0.67 log units) below the measured one; measured number outside the range, above it.
By their numbers in this assay, from the lowest: compound 2; then compounds 3 and 1 (each within the scatter of the next); then compound 4.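

In this assay, ethyl on this ring, with only 2 heavy atoms and no ring of its own, gives a 6.7-fold higher number from compound 2 to compound 4 (0.82 log units; beyond the scatter). Together with a 2.4-fold higher number from compound 2 to compound 3 (0.38 log units; beyond the scatter), that makes two additions to this ring, and both raise the number, so even a small chain here is not a neutral change. Nothing available explains this rise. Going by these compounds, whether methyl or a fluorine atom in the same place would leave the number of compound 2 unchanged stays open, as does whether ethyl elsewhere on the ring would give the same step.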